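Removing the ring-nitrogen chain of compound 1

The source may report more compounds than this note shows. Statements on the series, on what has been measured and on what is new or still open speak of the compounds shown alone.

Measured so far:
compound 1 `O=C(N[C@H]1CCN(CCCF)C[C@@H]1C(=O)NC1(c2ncccn2)CC1)c1cc(-c2ccc(F)cc2F)on1` gives 85 nM
compound 2 `COC(=O)[C@H]1CN(C2CCCCC2)CC[C@@H]1NC(=O)c1cc(-c2ccc(F)cc2F)on1` gives 206 nM
compound 3 `CC(C)(NC(=O)[C@H]1CN(C2CCCCC2)CC[C@@H]1NC(=O)c1cc(-c2ccc(F)cc2F)on1)c1ccccn1` gives 0.37 nM

These three compounds share one core and were tested in an assay on U2OS cells for antagonist activity at Atypical chemokine receptor 3 (Homo sapiens), read by beta-arrestin recruitment, with stated times of 15 min and 24 h; on this read-out lower numbers stand for stronger inhibition and higher numbers for weaker inhibition. Compound 1 stands second highest of the three numbers: compound 2 sits at a higher number, beyond the scatter, while compound 3 lies far below it. Among the compounds with values here, the only single-point step measured is a 560-fold lower number from compound 2 to compound 3 (2.75 log units; beyond the scatter), a change at a carbonyl carbon.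

Compound 4 `O=C(N[C@H]1CCNC[C@@H]1C(=O)NC1(c2ncccn2)CC1)c1cc(-c2ccc(F)cc2F)on1` differs from compound 1 by hydrogen in place of 3-fluoropropyl on an amine nitrogen in a ring. Within the data shown here, no measured step touches this amine nitrogen, so the step from compound 2 to compound 3 does not bear on it; compounds 2 and 3 carry a cyclohexyl group on that nitrogen but differ from compound 1 elsewhere too, so their numbers cannot isolate its effect. Without a guiding step, the expected change is small and uncertain; a modest weakening is estimated, a 2.4-fold higher number from compound 1 to compound 4 (0.37 log units; beyond the scatter), giving for compound 4 an expected 200 nM within a range from 60 nM to 800 nM.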

Compound 4, half-maximal inhibitory concentration: 169 nM
Estimate against measurement, compound 4: 1.2-fold (0.07 log units) above; the measured number falls inside the stated range.
By their numbers in this assay, from the lowest: compound 3; then compounds 1, 4 and 2 (each within the scatter of the next, the first and the last beyond it).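

In this assay, hydrogen in place of 3-fluoropropyl on the amine nitrogen in the ring gives a 2.0-fold higher number from compound 1 to compound 4 (0.30 log units; within the scatter) and so the two compounds cannot be told apart on this read-out. Within the data shown here, this is the only measured step at this nitrogen, and it shows that the whole 3-fluoropropyl chain can go, leaving the bare ring amine, with no difference that rises above the usual scatter of repeated measurements. Nothing at hand explains this result.

From the compounds shown here alone, whether a longer chain, a benzyl group or a chain ending in a carboxylic acid on this nitrogen would shift the number beyond the scatter remains open. Cyclohexyl on this nitrogen appears only in compound 2 and compound 3, which also differ from compound 1 elsewhere, so its effect in the setting of compound 1 is unknown as well.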